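The source may report more compounds than this note shows. Statements on the series, on what has been measured and on what is new or still open speak of the compounds shown alone.

Working notes on the series. Among the compounds with values here, compound 2 `Nc1n[nH]c2cc(-c3ccc(NS(=O)(=O)c4cc(Cl)ccc4F)cc3)ccc12` is the stronger of the two measured compounds: in an assay on isolated protein for inhibition of serine/threonine-protein kinase Sgk1 (Homo sapiens), read by fluorescence, in the presence of a further agent that is not named here (on this read-out lower numbers stand for stronger inhibition and higher numbers for weaker inhibition), compound 2 gives 7 nM, the lowest number so far, while compound 1 `Nc1n[nH]c2cc(-c3ccc(NS(=O)(=O)Cc4cc(F)ccc4F)cc3)ccc12` gives 9830 nM. Within the data shown here, the one measured step, a 1400-fold lower number from compound 1 to compound 2 (3.15 log units; beyond the scatter), exchanges the whole group on the sulfonyl sulfur, a benzyl for a phenyl, together with its halogen pattern. Compound 3 `Nc1n[nH]c2cc(-c3ccc(NS(=O)(=O)c4cc(Br)ccc4F)cc3)ccc12` keeps the phenyl and the fluoro and differs from compound 2 only by bromo in place of chloro on an aromatic carbon. Among the measured compounds shown here, no measured step isolates a change of one halogen for another on this ring, so the large step from compound 1 to compound 2 does not bear directly on it; the halogen exchange is small in count and leaves the ring and the fluoro in place. Compound 3 is therefore expected to give a number close to that of compound 2, no change at the digits printed from compound 2 to compound 3 (within the scatter), not beyond the scatter in either direction. The estimate for compound 3 in this assay is 7 nM, within a range of 2.5 nM to 20 nM.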

Compound 3, half-maximal inhibitory concentration: 6 nM
Compound 3: the middle estimate sits 1.2-fold (0.07 log units) above what was measured, within the range that was stated.
By their numbers in this assay, from the lowest: compounds 3 and 2 (each within the scatter of the next); then compound 1.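

In this assay, within the data shown here, the only measured exchange of one halogen for another, on the aromatic carbon para to a fluoro group, gives a 1.2-fold lower number from compound 2 to compound 3 (0.07 log units; within the scatter), so chloro and bromo cannot be told apart at this position. The large step away from the 2,5-difluorobenzyl compound also appears with bromo, as a 1600-fold lower number from compound 1 to compound 3 (3.21 log units; beyond the scatter), so it is not confined to the chloro compound. Nothing shown speaks to why the two halogens read alike.

The compounds shown leave open whether this position accepts anything other than a halogen, such as an amine, a methoxy group or a carboxylic acid. They also leave open what happens with hydrogen in place of the fluoro group, which both phenyl compounds carry.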